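This account rests on a few compounds, and the source may have more. Where it says the series, first, only, none or still open, it means among the compounds named here.

In a functional assay on 143B cells (Homo sapiens) for inhibition, read by MTT assay, with a stated time of 72 h (a lower number here means a stronger inhibitor, a higher number a weaker inhibitor), compound 1 `O=C(O)CCC(=O)OCCCCCCSc1ccc([N+](=O)[O-])c2nonc12` gives 2830 nM, compound 2 `O=C(CCC(=O)OCCCCCCSc1ccc([N+](=O)[O-])c2nonc12)Nc1ccccc1` gives 3850 nM and compound 3 `O=C(CCC(=O)OCCCCCCSc1ccc([N+](=O)[O-])c2nonc12)Nc1cccc(Cl)c1` gives 2890 nM. Compound 3 therefore sits together with the other two. All three numbers lie within the scatter of one another, so these data do not rank them.

Compound 4 `Cc1ccc(NC(=O)CCC(=O)OCCCCCCSc2ccc([N+](=O)[O-])c3nonc23)cc1` keeps the shared core and changes only the group at the far end of the molecule: 4-methylphenyl in place of 3-chlorophenyl on an amide-type nitrogen. In words, 4-methylphenyl stands in place of 3-chlorophenyl on an amide-type nitrogen.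

For the measured compounds named here, three measured steps bear on this change. Anilino in place of hydroxy on a carbonyl carbon gives a 1.4-fold higher number from compound 1 to compound 2 (0.13 log units; within the scatter). (3-Chlorophenyl)amino in the same place gives a 1.0-fold higher number from compound 1 to compound 3 (0.01 log units; within the scatter). Chloro in place of hydrogen on an aromatic carbon gives a 1.3-fold lower number from compound 2 to compound 3 (0.12 log units; within the scatter). All three are small and lie within the scatter, so no change at this end has yet moved the number measurably. Going by the values given here, no measured compound carries 4-methylphenyl, so the evidence is indirect and favours no direction.

No step beyond the scatter is therefore expected in this assay. The estimate amounts to an expected 1.1-fold higher number from compound 3 to compound 4 (0.04 log units; within the scatter). For compound 4 the expected value is 3200 nM, with an estimated range from 1800 nM to 5500 nM.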

Compound 4, half-maximal inhibitory concentration: 3250 nM
For compound 4 the middle estimate is 1.0-fold (0.01 log units) below the measured one, and the stated range covers the measured number.
By their numbers in this assay, from the lowest: compounds 1, 3, 4 and 2 (each within the scatter of the next).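

In this assay, 4-methylphenyl in place of 3-chlorophenyl on the amide-type nitrogen leaves the number within the scatter (a 1.1-fold higher number from compound 3 to compound 4 (0.05 log units; within the scatter)), so a methyl-bearing ring reads the same as a chlorine-bearing one. The same holds when methyl stands in place of hydrogen on the plain phenyl ring (a 1.2-fold lower number from compound 2 to compound 4 (0.07 log units; within the scatter)) and when the whole (4-methylphenyl)amino group stands in place of the hydroxy of the free acid (a 1.1-fold higher number from compound 1 to compound 4 (0.06 log units; within the scatter)). Four different ends of the molecule (hydroxy, anilino, (3-chlorophenyl)amino and (4-methylphenyl)amino) now give numbers that cannot be told apart in this assay, and nothing shown here explains why they read alike.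

As far as these compounds go, every ring at this end so far is a phenyl ring, so it remains open whether a saturated ring such as cyclohexyl, or an end group carrying an amine such as piperidine or morpholine, would also leave the number where it is. Also open, from the compounds shown here alone, is what a longer chain between the ester and the sulfur, or a change within the shared core itself, would do to the number, since all four compounds keep both unchanged.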